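This account rests on a few compounds, and the source may have more. Where it says the series, first, only, none or still open, it means among the compounds named here.

Measured compounds in an assay on microsomes for inhibition of acyl-CoA:cholesterol acyltransferase (Oryctolagus cuniculus); on this read-out lower numbers stand for stronger inhibition and higher numbers for weaker inhibition:
compound 1, `CC(C)c1cccc(C(C)C)c1NC(=O)NCC1(c2ccc(C(C)(C)C)cc2)CCCC1`, gives 63 nM
compound 2, `COc1cccc(C2(CNC(=O)Nc3c(C(C)C)cccc3C(C)C)CCCC2)c1`, gives 13 nM
compound 3, `CC(C)c1cccc(C(C)C)c1NC(=O)NCC1(c2ccc(C(F)(F)F)cc2)CCCC1`, gives 66 nM

Compound 2 holds the lowest number of the three; the gaps to the other two are beyond the scatter, namely a 4.8-fold lower number from compound 1 to compound 2 (0.69 log units; beyond the scatter) and a 5.1-fold higher number from compound 2 to compound 3 (0.71 log units; beyond the scatter). Compounds 1 and 3 sit together, the step between them being a 1.0-fold higher number from compound 1 to compound 3 (0.02 log units; within the scatter).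

Compound 4, `CC(C)c1cccc(C(C)C)c1NC(=O)NCC1(c2ccc(NCCO)cc2)CCCC1`, differs from compound 2 in that (4-((2-hydroxyethyl)amino)phenyl in place of 3-methoxyphenyl on a saturated ring carbon). The two measured steps that bear on this both involve the 3-methoxyphenyl: replacing 4-(tert-butyl)phenyl by it lowered the number by a 4.8-fold lower number from compound 1 to compound 2 (0.69 log units; beyond the scatter), and replacing it by 4-(trifluoromethyl)phenyl raised the number by a 5.1-fold higher number from compound 2 to compound 3 (0.71 log units; beyond the scatter). In both cases the 3-methoxyphenyl gives the lower number against a 4-substituted phenyl. Among the compounds with values here, no measured compound carries a 4-((2-hydroxyethyl)amino)phenyl or any group with hydrogen-bond donors at that place, so the size is uncertain. A modest rise is expected, of the order of a 4.6-fold higher number from compound 2 to compound 4 (0.66 log units; beyond the scatter). Compound 4 is therefore estimated at 60 nM, within a range of 15 nM to 250 nM.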

Compound 4, half-maximal inhibitory concentration: 25 nM
Compound 4: middle estimate off by 2.4-fold (0.38 log units), on the high side; the measured number falls inside the stated range.
By their numbers in this assay, from the lowest: compounds 2 and 4 (each within the scatter of the next); then compounds 1 and 3 (each within the scatter of the next).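

In this assay, within the data shown here, the 4-((2-hydroxyethyl)amino)phenyl on the saturated ring carbon, the only group here with hydrogen-bond donors at this place, is not separated from the 3-methoxyphenyl (a 1.9-fold higher number from compound 2 to compound 4 (0.28 log units; within the scatter)). A 4-substituted phenyl therefore need not give the higher number: (2-hydroxyethyl)amino gives a lower number than trifluoromethyl (a 2.6-fold lower number from compound 3 to compound 4 (0.42 log units; beyond the scatter)) and tert-butyl (a 2.5-fold lower number from compound 1 to compound 4 (0.40 log units; beyond the scatter)). No measurement available here accounts for these steps.

The 3-methoxyphenyl and the 4-((2-hydroxyethyl)amino)phenyl differ in both substituent and attachment, so the compounds shown cannot separate the effect of one from the other. From the compounds shown here alone, it also remains open how a plain amine, a longer chain ending in hydroxyl or a carboxylic acid would compare with the (2-hydroxyethyl)amino on this phenyl.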